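Working notes: removing the fluoro group from compound 2

The compounds below may be only part of what the source reports. "The series", "measured", "known", "first", "only" and "open" are said of these compounds alone.

Values so far come from a functional assay on HT-29 cells (Homo sapiens) for antiproliferative activity, read by sulforhodamine B assay, with a stated time of 48 h (on this read-out lower numbers stand for stronger inhibition and higher numbers for weaker inhibition), and stand as follows:
- compound 1 `O=C1NCCN1c1ccc(S(=O)(=O)Nc2ccc3[nH]ccc3c2)cc1` gives 130 nM as its half-maximal inhibitory concentration
- compound 2 `O=C1NCCN1c1ccc(S(=O)(=O)Nc2ccc(F)cc2)cc1` gives 370 nM as its half-maximal inhibitory concentration

Compound 2 holds the higher of the two numbers, and its gap to compound 1 lies beyond the usual scatter. Still unmeasured is compound 3 `O=C1NCCN1c1ccc(S(=O)(=O)Nc2ccccc2)cc1` in which the 4-fluorophenyl of compound 2 becomes phenyl. This is hydrogen in place of fluoro on an aromatic carbon, para to a large group, and the counted difference reads hydrogen in place of fluoro on an aromatic carbon in full. For the measured compounds named here, no step that changes a single place has yet been measured. The expectation therefore rests only on compound 2 at 370 nM and on the structural change. A slight rise in the number is expected, with the estimated 1.2-fold higher number from compound 2 to compound 3 (0.09 log units; within the scatter) staying within the scatter in this assay and no real change anticipated. Compound 3 is estimated at 450 nM with 180 nM to 1100 nM as the expected range.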

Compound 3, half-maximal inhibitory concentration: 280 nM
Compound 3: the middle estimate sits 1.6-fold (0.21 log units) above what was measured; the range from low to high includes it.
By their numbers in this assay, from the lowest: compound 1; then compounds 3 and 2 (each within the scatter of the next).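

For the compounds shown here, the first single-place step, hydrogen in place of fluoro on an aromatic carbon, para to a large group, reads in this assay as a 1.3-fold lower number from compound 2 to compound 3 (0.12 log units; within the scatter) and so counts as no real change. At this position, then, the fluoro is not required for the activity seen with compound 2, and 4-fluorophenyl and phenyl cannot be told apart on this read-out. No measurement on hand speaks to why the two read alike.

As far as these compounds go, this single pair covers only fluoro and hydrogen, so it does not show how much the position tolerates: whether a methoxy, an amine or a carboxylic acid on the same aromatic carbon would leave the number within the scatter of compound 3 or move it beyond that remains open. Also open is whether fluoro and hydrogen would read alike on a different aromatic carbon of the same ring, since only the one placement appears among these compounds.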